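Swapping methoxy for chloro on a weak antiproliferative compound

The source may hold more compounds than are shown below. What is called first, only, known or untested is meant among the compounds shown, and "the series" means these compounds.

Measured so far:
compound 1 `COc1ccc(N2C(=O)COc3ccc(-c4cnc(Cl)c(NS(=O)(=O)c5ccc(F)cc5)c4)cc32)cc1`: 30100 nM
compound 2 `COc1cccc(N2C(=O)COc3ccc(-c4cccc(NS(=O)(=O)c5ccc(F)cc5)c4)cc32)c1`: > 40000 nM

Within the data shown here, in a functional assay on HCT-116 cells (Homo sapiens) for antiproliferative activity, read by MTT assay, with a stated time of 72 h (a higher number here means a weaker inhibitor, a lower number a stronger inhibitor), compound 1 gives 30100 nM, the only true number so far. Compound 2 reads > 40000 nM, which is a limit of the assay and not a number. Compound 3 `O=C1COc2ccc(-c3cnc(Cl)c(NS(=O)(=O)c4ccc(F)cc4)c3)cc2N1c1ccc(Cl)cc1` keeps the core of compound 1 but carries chloro in place of methoxy on an aromatic carbon, para to a large group (chloro in place of methoxy on an aromatic carbon). Among the measured compounds shown here, no measured pair shows this change, so no step beyond the scatter is expected in this assay. The expected change is a 1.2-fold lower number from compound 1 to compound 3 (0.08 log units; within the scatter). The estimate for compound 3 is 25000 nM, expected to fall between 10000 nM and 50000 nM.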

Compound 3, half-maximal inhibitory concentration: 27900 nM
Compound 3: middle estimate off by 1.1-fold (0.05 log units), on the low side; low and high end bracket the measured number.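

Among these compounds, exchanging 4-methoxyphenyl for 4-chlorophenyl on the shared core gives a 1.1-fold lower number from compound 1 to compound 3 (0.03 log units; within the scatter) in this assay, the only direct reading of a change at this position. Methoxy is therefore not required for the modest activity seen here, and chloro serves equally well in its place. The pair sits close to the top of the readable range, which leaves little room to detect a loss: the limit of > 40000 nM in this assay, at which 1 of the 3 values shown sits.

From the compounds shown here alone, whether an amine or a carboxylic acid at this position would shift the number beyond the scatter stays open. So does whether this exchange would give the same result on a different core.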